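A Chloro Substituent Tested on Two Related Cores

A few compounds are considered here, and "the series" means these few. Any claim that something is new, unique, unknown or untested is made for them only; others in the source may bear on it.

Compound 1 `O=C/C=C/c1ccccc1OCc1ccccc1` and compound 2 `O=C/C=C/c1ccccc1OCc1ccc(Cl)cc1` share one core and differ in a single group. In a functional assay on cells (Neutrophil, Rattus norvegicus, strain Sprague-Dawley) for inhibition (on this read-out lower numbers stand for stronger inhibition and higher numbers for weaker inhibition), compound 1 gives 6400 nM and compound 2 gives 7400 nM. The step of a 1.2-fold higher number from compound 1 to compound 2 (0.06 log units; within the scatter) comes from the change (chloro in place of hydrogen on an aromatic carbon). Compound 3 `COc1ccc(OCc2ccccc2)c(/C=C/C=N/O)c1` is built on a second core; the difference between the two cores is not broken down here. In this assay compound 3 gives 4300 nM, and its distance from compound 1 and from compound 2 stays within the usual scatter, so no order among the three can be read from these numbers. Compound 4 `COc1ccc(OCc2ccccc2Cl)c(/C=C/C=N/O)c1` has not yet been measured. It differs from compound 3 by chloro in place of hydrogen on an aromatic carbon, the same kind of change as from compound 1 to compound 2, though here the chloro sits ortho to a large group rather than para to it. Because the earlier step of a 1.2-fold higher number from compound 1 to compound 2 (0.06 log units; within the scatter) stayed within the scatter, a similar small step is expected here, namely a 1.2-fold higher number from compound 3 to compound 4 (0.07 log units; within the scatter). Compound 4 is therefore estimated to give 5000 nM in this assay, with a likely range from 2500 nM to 10000 nM.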

Compound 4, half-maximal inhibitory concentration: 9500 nM
Estimate against measurement, compound 4: 1.9-fold (0.28 log units) below; the measured number falls inside the stated range.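

On the second core, chloro in place of hydrogen gives a 2.2-fold higher number from compound 3 to compound 4 (0.34 log units; beyond the scatter) in this assay, a modest weakening of inhibition. Set beside the earlier step, this does not show that the change acts differently on the two cores: the same change on two cores in this assay, a 1.2-fold higher number (0.06 log units; within the scatter) from compound 1 to compound 2 and a 2.2-fold higher number (0.34 log units; beyond the scatter) from compound 3 to compound 4, 1.9-fold (0.28 log units) apart, within the scatter of two such steps. Nor does it prove that the change carries over unaltered, as there are only two pairs, and in compound 4 the chloro sits ortho to a large group, unlike in compound 2, so core and place vary together.

The compounds shown leave open whether another group in place of the chloro, such as a fluoro, an amine or a carboxylic acid, would shift the number in the same way on both cores. They also leave open what a chloro does at other places on the phenyl ring of the second core, where a closer match to the pair of compound 1 and compound 2 could be found.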